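Trifluoromethyl for Methyl on the Sulfonyl Aryl Ring

A few compounds are considered here, and "the series" means these few. Any claim that something is new, unique, unknown or untested is made for them only; others in the source may bear on it.

Of the compounds shown here, two of a shared core have been measured in an assay on CHO cells for displacement of a labelled ligand from prostaglandin E2 receptor EP1 subtype (Homo sapiens); on this read-out higher numbers stand for weaker inhibition and lower numbers for stronger inhibition. Compound 1 `CCOc1ccc(Cc2nnc(CN(c3cccc(Cl)c3Cl)S(=O)(=O)c3ccc(C(F)(F)F)cc3)o2)cc1` gives 2.51 nM, while compound 2 `COc1ccc(Nc2nnc(CN(c3cccc(Cl)c3Cl)S(=O)(=O)c3ccc(C)cc3)o2)cc1` gives 39.8 nM, the higher of the two numbers, set apart from compound 1 by a gap well beyond the usual scatter. Compound 3 `COc1ccc(Nc2nnc(CN(c3cccc(Cl)c3Cl)S(=O)(=O)c3ccc(C(F)(F)F)cc3)o2)cc1` is compound 2 with one change: trifluoromethyl in place of methyl on an aromatic carbon. Compound 1, which carries the same trifluoromethyl group alongside other differences, sits at 2.51 nM; a step toward lower numbers is therefore plausible, though of moderate size. For compound 3 the expected value is 15 nM, between 4 nM and 60 nM, an estimated step of a 2.7-fold lower number from compound 2 to compound 3 (0.42 log units; beyond the scatter) in this assay.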

Compound 3, half-maximal inhibitory concentration: 7.94 nM
The estimate for compound 3 lay 1.9-fold (0.28 log units) above the measured number, and the stated range covers the measured number.
By their numbers in this assay, from the lowest: compound 1; then compound 3; then compound 2.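

With the (4-methoxyphenyl)amino group held constant, trifluoromethyl in place of methyl gives a 5.0-fold lower number from compound 2 to compound 3 (0.70 log units; beyond the scatter) in this assay and isolates the effect of this change, which compounds 1 and 2 could not do. With trifluoromethyl held constant, (4-methoxyphenyl)amino in place of 4-ethoxybenzyl gives a 3.2-fold higher number from compound 1 to compound 3 (0.50 log units; beyond the scatter) and separates the second difference. No measurement available here explains either step.

Going by these compounds, it remains open whether a chlorine atom or a nitrile at this position would lower the number as well, and whether the methyl-to-trifluoromethyl step holds with 4-ethoxybenzyl in the molecule.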